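Permeability of a furan-to-benzyl pair and its phenoxy partner

The source may report more compounds than this note shows. Statements on the series, on what has been measured and on what is new or still open speak of the compounds shown alone.

Of the compounds shown here, three built on one shared core have been measured in an ADME assay for permeability, using PAMPA, with a stated time of 30 min, at pH 7.4; on this read-out lower numbers stand for lower permeability and higher numbers for higher permeability. Compound 1 `Fc1ccc(-c2ccc3c(NCCCNCc4ccco4)ccnc3c2)cc1` gives 237 10^-6 cm/s. Compound 2 `CN(C)c1cccc(Oc2ccc3c(NCCCNCc4ccco4)ccnc3c2)c1` gives 317 10^-6 cm/s. Compound 3 `COc1ccc(F)cc1CNCCCNc1ccnc2cc(-c3ccc(F)cc3)ccc12` gives 237 10^-6 cm/s. Compound 4 `COc1ccc(F)cc1CNCCCNc1ccnc2cc(Oc3cccc(N(C)C)c3)ccc12` is not yet measured.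

Compound 2 differs from compound 1 by 3-(dimethylamino)phenoxy in place of 4-fluorophenyl on an aromatic carbon, and this assay records a 1.3-fold higher number from compound 1 to compound 2 (0.13 log units; within the scatter). Compound 3 differs from compound 1 by 5-fluoro-2-methoxyphenyl in place of furan-2-yl on a saturated chain carbon bound to an amine nitrogen, with no change at the digits printed from compound 1 to compound 3 (within the scatter). Compound 3 and compound 1 therefore stand level at the digits given, and all three measured numbers lie close together.

The step from compound 3 to compound 4 is 3-(dimethylamino)phenoxy in place of 4-fluorophenyl on an aromatic carbon. Within the data shown here, this is the same change as the one from compound 1 to compound 2: the group that leaves, the group that enters and the place are described in the same words. The two starting points differ only in the group on the chain carbon bound to the amine nitrogen, as told by 5-fluoro-2-methoxyphenyl in place of furan-2-yl on a saturated chain carbon bound to an amine nitrogen, and that difference left this assay unchanged.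

On this basis the step from compound 3 to compound 4 is expected to be about a 1.3-fold higher number from compound 3 to compound 4 (0.10 log units; within the scatter), resting on compound 1 and compound 2 having shown a 1.3-fold higher number from compound 1 to compound 2 (0.13 log units; within the scatter). Compound 4 is estimated at 300 10^-6 cm/s in this assay, with a range from 180 10^-6 cm/s to 480 10^-6 cm/s expected to hold most repeat measurements.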

Compound 4, apparent permeability: 317 10^-6 cm/s
The estimate for compound 4 lay 1.1-fold (0.02 log units) below the measured number; measured number inside the range.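

In this assay the exchange of 4-fluorophenyl for 3-(dimethylamino)phenoxy on the core bearing the 5-fluoro-2-methoxyphenyl group gives a 1.3-fold higher number from compound 3 to compound 4 (0.13 log units; within the scatter) and matches the step seen on the core bearing furan-2-yl: the same change on two cores in this assay, a 1.3-fold higher number (0.13 log units; within the scatter) from compound 1 to compound 2 and a 1.3-fold higher number (0.13 log units; within the scatter) from compound 3 to compound 4, 1.0-fold (0.00 log units) apart, within the scatter of two such steps. The second exchange, read on the cores bearing 3-(dimethylamino)phenoxy, gives no change at the digits printed from compound 2 to compound 4 (within the scatter) and likewise matches its earlier counterpart: the same change on two cores in this assay, no change at the digits printed (within the scatter) from compound 1 to compound 3 and no change at the digits printed (within the scatter) from compound 2 to compound 4, 1.0-fold (0.00 log units) apart, within the scatter of two such steps. The four compounds therefore show that each change read the same on both cores, but every step lies within the scatter, so they do not show that either change has a real effect on this read-out, nor that the agreement would extend beyond these two pairs.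

The compounds shown leave open whether a step beyond the scatter would carry over in the same way, for instance with a morpholine or a carboxylic acid on the aromatic carbon in place of 3-(dimethylamino)phenoxy. They also leave open how a pyridine ring or a cyclohexyl group in place of furan-2-yl, or a longer chain linking the two amines, would read in this assay.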